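Pyridyl for Tolyl at the Aryl Position of Compound 2

The source may hold more compounds than are shown below. What is called first, only, known or untested is meant among the compounds shown, and "the series" means these compounds.

Compound 1: `CC(Oc1ccccc1-c1ccc([N+](=O)[O-])cc1)C1=NCCN1`, 501 nM in an assay on CHO cells for displacement of a labelled ligand from Alpha-2B adrenergic receptor (Homo sapiens); a lower number here means a stronger inhibitor, a higher number a weaker inhibitor
Compound 2: `Cc1ccc(-c2ccccc2OC(C)C2=NCCN2)cc1`, 398 nM

Among the measured compounds shown here, compound 2 shows the lowest of the two numbers measured so far in this assay, but its nearest neighbour, compound 1, sits within the scatter of it, so no order between the two can be claimed. For the measured compounds named here, the one measured step, a 1.3-fold lower number from compound 1 to compound 2 (0.10 log units; within the scatter), changed a substituent on the same distal aromatic ring and produced no shift beyond the scatter.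

Compound 3 is `CC(Oc1ccccc1-c1cccnc1)C1=NCCN1`. It differs from compound 2 by pyridin-3-yl in place of 4-methylphenyl on an aromatic carbon. Going by the values given here, no measured step replaces the whole ring, so the step from compound 1 to compound 2 bears on it only loosely, suggesting that alterations at this position have so far been tolerated. Compound 3 is therefore expected to give a number close to that of compound 2, with wide uncertainty. The expected step is a 1.6-fold higher number from compound 2 to compound 3 (0.20 log units; within the scatter). For compound 3 the estimate is 630 nM, with a range from 200 nM to 2000 nM.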

Compound 3, inhibition constant: 933 nM
Compound 3: the middle estimate sits 1.5-fold (0.17 log units) below what was measured; the measured number falls inside the stated range.
By their numbers in this assay, from the lowest: compounds 2, 1 and 3 (each within the scatter of the next, the first and the last beyond it).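

In this assay, exchanging the whole 4-methylphenyl ring for pyridin-3-yl gave the first shift beyond the scatter at this position, a 2.3-fold higher number from compound 2 to compound 3 (0.37 log units; beyond the scatter), though only a modest one. The earlier substituent change, a 1.3-fold lower number from compound 1 to compound 2 (0.10 log units; within the scatter), had suggested that this position tolerates alteration, but compound 3 shows that this tolerance does not extend to every change made there. No available evidence explains the shift, and these compounds cannot separate the entering ring nitrogen from the loss of the methyl group.

The compounds shown leave open whether an unsubstituted phenyl ring would give a number near that of compound 2 or compound 3. They also leave open whether pyridin-4-yl, or a pyridine ring carrying a methyl group, would behave as pyridin-3-yl does.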